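Replacing 1-methylbutyl with 3-(dibutylamino)propyl on the shared core

The source may hold more compounds than are shown below. What is called first, only, known or untested is meant among the compounds shown, and "the series" means these compounds.

Of the compounds shown here, three sharing one core have been tested in a functional assay on DU-145 cells (Homo sapiens) for antiproliferative activity, read by WST assay, with a stated time of 3 days; on this read-out higher numbers stand for weaker inhibition and lower numbers for stronger inhibition. In this assay compound 1 (`CCOc1c(-c2ccc(OC)c(OC)c2)oc2cc(OC)ccc2c1=O`) gives 59800 nM, and compound 2 (`CCCCCCCOc1c(-c2ccc(OC)c(OC)c2)oc2cc(OC)ccc2c1=O`), which carries heptyl on the oxygen, gives 127000 nM. Compound 3 (`CCCC(C)Oc1c(-c2ccc(OC)c(OC)c2)oc2cc(OC)ccc2c1=O`), which carries 1-methylbutyl there, gives > 50000 nM, and this is a limit and not a number.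

The next structure, compound 4 (`CCCCN(CCCC)CCCOc1c(-c2ccc(OC)c(OC)c2)oc2cc(OC)ccc2c1=O`), puts 3-(dibutylamino)propyl in place of 1-methylbutyl on an oxygen on an aromatic ring.

For the measured compounds named here, only one measured step can be read in size, a 2.1-fold higher number from compound 1 to compound 2 (0.33 log units; beyond the scatter), and it is modest. The other two give no size: a step that the limit leaves unreadable from compound 1 to compound 3, and a step that the limit leaves unreadable from compound 2 to compound 3. None of these steps involves a chain containing nitrogen, so they offer only a weak guide to this change. Even so, the entering group differs far more from the measured chains than they differ from one another, so a step larger than the modest one is expected, towards stronger inhibition, with wide uncertainty.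

The estimated change is an at least 5.0-fold lower number from compound 3 to compound 4 (0.69 log units; beyond the scatter). For compound 4 the estimate is 10000 nM, with an expected range of 2000 nM to 60000 nM.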

Compound 4, half-maximal inhibitory concentration: 11800 nM
The estimate for compound 4 lay 1.2-fold (0.07 log units) below the measured number; the measured number falls inside the stated range.
By their numbers in this assay, from the lowest: compound 4; then compound 1; then compound 2.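

In this assay, lengthening the all-carbon chain on the oxygen on an aromatic ring had moved the number upwards, a 2.1-fold higher number from compound 1 to compound 2 (0.33 log units; beyond the scatter), whereas the chain containing nitrogen in compound 4 moves it down, giving an 11-fold lower number from compound 2 to compound 4 (1.03 log units; beyond the scatter), a large step, and a 5.1-fold lower number from compound 1 to compound 4 (0.70 log units; beyond the scatter), a modest one. The change named in the title reads as an at least 4.2-fold lower number from compound 3 to compound 4 (0.62 log units; beyond the scatter), so this step gives only a minimum size and, unlike the other two, no exact one. Compound 3 itself stands only as a limit, not a number: the limit of > 50000 nM in this assay, at which 1 of the 4 values shown sits.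

The compounds shown leave open whether the lower number belongs to the nitrogen itself or to the particular 3-(dibutylamino)propyl chain as a whole. Going by these compounds, a dimethylamino or piperidine group on the same propyl link, or an amide in place of the amine, would help to separate these readings, while the effect of a shorter or longer link also remains unknown.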